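This account rests on a few compounds, and the source may have more. Where it says the series, first, only, none or still open, it means among the compounds named here.

Of the compounds shown here, three have numbers so far in a physicochemical assay for solubility, at pH 7.4; a lower number here means a less soluble compound, a higher number a more soluble compound. Compound 1 `CN1CCN(c2cccc(C(=O)/C=C/c3ccc(/C=C/C(=O)NO)cc3)c2)CC1` gives 16000 nM and compound 2 `O=C(/C=C/c1cc(/C=C/C(=O)c2ccccc2)ccn1)NO` gives 15000 nM, so these two sit within the usual scatter of each other. Compound 3 `CN1CCN(c2cccc(C(=O)/C=C/c3cccc(/C=C/C(=O)NO)n3)c2)CC1` gives 380000 nM, well beyond the scatter and higher than both. Compound 1 therefore stands level with compound 2 and far under compound 3.

The next compound, compound 4 `O=C(/C=C/c1ccc(/C=C/C(=O)c2ccccc2)cc1)NO`, has hydrogen in place of 4-methylpiperazin-1-yl on an aromatic carbon of compound 1 (hydrogen in place of 4-methylpiperazin-1-yl on an aromatic carbon). Within the data shown here, no measured pair shows this change alone. The nearest hint is that compound 3, which carries 4-methylpiperazin-1-yl, gives 380000 nM, while compound 2, which lacks it, gives 15000 nM, though those two also differ elsewhere in the core. On this thin evidence, a downward step beyond the scatter is expected in this assay. The estimated step is a 6.4-fold lower number from compound 1 to compound 4 (0.81 log units; beyond the scatter). For compound 4 the estimated value is 2500 nM, with an expected range of 500 nM to 10000 nM.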

Compound 4, solubility: 3000 nM
Estimate against measurement, compound 4: 1.2-fold (0.08 log units) below, and the stated range covers the measured number.
By their numbers in this assay, from the lowest: compound 4; then compounds 2 and 1 (each within the scatter of the next); then compound 3.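

Among these compounds, this is the first pair that differs in one place alone. In this assay, hydrogen in place of 4-methylpiperazin-1-yl on an aromatic carbon gives a 5.3-fold lower number from compound 1 to compound 4 (0.73 log units; beyond the scatter), so this change can now be read directly, without a second difference in the core. The step lies beyond the scatter, which shows that the number at this place, meta to a large group, depends on which of these two substituents is present on the core of compound 1. The data offer no measurement that explains this step.

Still open, on these data alone, is whether the same change would give a similar step on the core of compound 3. As far as these compounds go, it is also open where a dimethylamino group or a carboxylic acid at this place would fall relative to compound 1 and compound 4.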